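Compound 4 near the assay limit

The compounds below may be only part of what the source reports. "The series", "measured", "known", "first", "only" and "open" are said of these compounds alone.

Of the compounds shown here, three sharing one core have been tested in a functional assay on SW982 cells (Homo sapiens) for inhibition, read by MTT assay, with a stated time of 72 h; on this read-out lower numbers stand for stronger inhibition and higher numbers for weaker inhibition. Compound 2 `COc1cc(OC)c(OC)cc1/C=C/C(=O)c1ccc(O)cc1O` gives 32400 nM. Compound 1 `COc1cc(OC)c(OC)cc1/C=C/C(=O)c1ccc(-c2c[nH]cn2)cc1` gives only a limit, > 150000 nM. Going by these compounds, compound 3 `COc1cc(OC)c(OC)cc1/C=C/C(=O)c1cc(Cl)ccc1O` also gives only a limit, > 150000 nM, so its true position is unknown. Compound 4 `COc1cc(OC)c(OC)cc1/C=C/C(=O)c1ccc(F)cc1` differs from it at one place: 4-fluorophenyl in place of 5-chloro-2-hydroxyphenyl on a carbonyl carbon. For the measured compounds named here, the one measured step at this carbonyl carbon, an at least 4.6-fold higher number from compound 2 to compound 3 (0.66 log units; beyond the scatter), is beyond the scatter, but it does not involve the incoming 4-fluorophenyl and offers only a loose guide. The data are dominated by the limit of > 150000 nM in this assay, at which 2 of the 3 values shown sit, so another weak result is the likely expectation. The expected step, an at least 1.1-fold lower number from compound 3 to compound 4 (0.06 log units; that floor lies within the scatter), is none beyond the scatter, and another limit is quite possible. Compound 4 is estimated at 130000 nM, with an expected range of 45000 nM to 300000 nM.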

Compound 4, half-maximal inhibitory concentration: 32500 nM
For compound 4 the middle estimate is 4.0-fold (0.60 log units) above the measured one; measured number below the stated range.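

Putting 4-fluorophenyl in place of 5-chloro-2-hydroxyphenyl on the carbonyl carbon gives an at least 4.6-fold lower number from compound 3 to compound 4 (0.66 log units; beyond the scatter), so a measurable value here needs no hydrogen-bond donor on this ring. Against 2,4-dihydroxyphenyl, the same group gives a 1.0-fold higher number from compound 2 to compound 4 (0.00 log units; within the scatter), so the two cannot be told apart in this test. Fluoro in place of 1H-imidazol-4-yl on an aromatic carbon gives an at least 4.6-fold lower number from compound 1 to compound 4 (0.66 log units; beyond the scatter).

Going by these compounds, the true size of the steps from compound 1 and compound 3 stays unknown: the limit of > 150000 nM in this assay, at which 2 of the 4 values shown sit. On these data alone, whether an amine or a carboxylic acid in place of the fluoro would give a lower number than compound 4 remains open.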